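The compounds below may be only part of what the source reports. "The series", "measured", "known", "first", "only" and "open" are said of these compounds alone.

In a functional assay on MCF7 cells (Homo sapiens) for antiproliferative activity, read by MTT assay, with a stated time of 72 h (a lower number here means a stronger inhibitor, a higher number a weaker inhibitor), compound 1 `CC(=O)O[C@H]1CC[C@]2(C)[C@H](CC[C@@](C)(O)[C@H]2CC[C@@H]2C(C)=CC[C@H]3[C@H](CC[C@]3(C)O)C2(C)C)OC1(C)C`, which carries a methyl on a carbonyl carbon of the shared core, gives 47900 nM. Compound 2 `CC1=CC[C@H]2[C@H](CC[C@]2(C)O)C(C)(C)[C@@H]1CC[C@H]1[C@]2(C)CC[C@H](OC(=O)NS(=O)(=O)c3ccc(C)cc3)C(C)(C)O[C@H]2CC[C@@]1(C)O`, with ((4-methylphenyl)sulfonyl)amino on that carbonyl carbon, reads > 50000 nM, which is a limit of the assay and not a number. Compound 3 `CC1=CC[C@H]2[C@H](CC[C@]2(C)O)C(C)(C)[C@@H]1CC[C@H]1[C@]2(C)CC[C@H](OC(=O)c3ccccc3F)C(C)(C)O[C@H]2CC[C@@]1(C)O`, with 2-fluorophenyl there, gives 11300 nM, the lowest number of the three and so the strongest inhibitor so far. Compound 4 `CC1=CC[C@H]2[C@H](CC[C@]2(C)O)C(C)(C)[C@@H]1CC[C@H]1[C@]2(C)CC[C@H](OC(=O)c3ccccc3C(F)(F)F)C(C)(C)O[C@H]2CC[C@@]1(C)O` is not yet measured. It has trifluoromethyl in place of fluoro on an aromatic carbon, ortho to a large group (trifluoromethyl in place of fluoro on an aromatic carbon).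

The closest evidence comes from changes at the same carbonyl carbon: a 4.2-fold lower number from compound 1 to compound 3 (0.63 log units; beyond the scatter) and an at least 4.4-fold lower number from compound 2 to compound 3 (0.64 log units; beyond the scatter). Neither step alters the group on the aromatic ring, so neither is a direct precedent, and no clear shift in either direction is expected in this assay. The expected step is a 1.2-fold higher number from compound 3 to compound 4 (0.06 log units; within the scatter), which stays within the scatter. For compound 4 the estimated value is 13000 nM, with an expected range from 5000 nM to 32000 nM.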

Compound 4, half-maximal inhibitory concentration: 19200 nM
The estimate for compound 4 lay 1.5-fold (0.17 log units) below the measured number; measured number inside the range.
By their numbers in this assay, from the lowest: compounds 3 and 4 (each within the scatter of the next); then compound 1. At a limit, above all of these: compound 2.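

In this assay, trifluoromethyl in place of fluoro on this aromatic carbon, ortho to a large group, gives a 1.7-fold higher number from compound 3 to compound 4 (0.23 log units; within the scatter) and so shows that the site takes four heavy atoms instead of one with no shift that stands out from the scatter. Going by these compounds alone, compound 4 also keeps a clear edge over the methyl group on the carbonyl carbon, with a 2.5-fold lower number from compound 1 to compound 4 (0.40 log units; beyond the scatter) showing that 2-fluorophenyl is not the only aromatic group there to beat methyl. The step of an at least 2.6-fold lower number from compound 2 to compound 4 (0.41 log units; beyond the scatter) is only a floor, as the reading for compound 2 is a limit of the assay and not a number: the limit of > 50000 nM in this assay, at which 1 of the 4 values shown sits.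

Still open, going by these compounds, is whether an amine or a methoxy group on this aromatic carbon would move the number beyond the scatter. Also open, on these data alone, is how a plain phenyl, with no group on its ring, would compare.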